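Swapping 3-aminophenyl for furan-2-yl on a shared core

The compounds below may be only part of what the source reports. "The series", "measured", "known", "first", "only" and "open" are said of these compounds alone.

This small set of compounds was tested in a functional assay on NCI-H460 cells (Homo sapiens) for antiproliferative activity, read by MTT assay, with a stated time of 48 h; a higher number here means a weaker inhibitor, a lower number a stronger inhibitor. Compound 1 `COc1ccc(-c2nc3cccc(-c4cc(OC)c(OC)c(OC)c4)c3o2)cc1OC` gives only a limit of the assay, > 25000 nM. Compound 2 `COc1ccc(-c2nc3cccc(-c4cc(OC)c(OC)c(OC)c4)c3o2)cc1F` gives 2800 nM, and compound 3 `COc1cc(-c2cccc3nc(-c4cccc(N)c4)oc23)cc(OC)c1OC` gives 2600 nM. Compound 3 therefore stands level with compound 2, and both lie well clear of the limit reached by compound 1.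

Compound 4 `COc1cc(-c2cccc3nc(-c4ccco4)oc23)cc(OC)c1OC` differs from compound 3 in one group: furan-2-yl in place of 3-aminophenyl on an aromatic carbon. Here furan-2-yl takes the place of 3-aminophenyl on an aromatic carbon of a five-membered aromatic ring with 1 nitrogen and 1 oxygen.

Three measured steps alter the group at this same place. They are an at least 8.9-fold lower number from compound 1 to compound 2 (0.95 log units; beyond the scatter), an at least 9.6-fold lower number from compound 1 to compound 3 (0.98 log units; beyond the scatter) and a 1.1-fold lower number from compound 2 to compound 3 (0.03 log units; within the scatter). So a swap here can matter a great deal or hardly at all, and no measured compound carries a furan-2-yl to settle which applies. Two of the three steps are large, so a wide range is warranted, and a modest move towards a higher number seems the likelier outcome in this assay. The expected change is a 1.9-fold higher number from compound 3 to compound 4 (0.28 log units; within the scatter), though this may not exceed the scatter by much. For compound 4 the estimated value is 5000 nM, within an expected range of 1300 nM to 22000 nM.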

Compound 4, half-maximal inhibitory concentration: 2600 nM
Estimate against measurement, compound 4: 1.9-fold (0.28 log units) above; the range from low to high includes it.
By their numbers in this assay, from the lowest: compounds 3, 4 and 2 (each within the scatter of the next). At a limit, above all of these: compound 1.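

Replacing 3-aminophenyl with furan-2-yl makes no visible difference in this assay, with no change at the digits printed from compound 3 to compound 4 (within the scatter), so at this place a five-membered ring with 0 hydrogen-bond donors serves as well as a six-membered ring carrying an amine. The comparison with the 3-fluoro-4-methoxyphenyl group gives the same picture, with a 1.1-fold lower number from compound 2 to compound 4 (0.03 log units; within the scatter), which means that three quite different groups at this place now lie within the scatter of one another. Only the 3,4-dimethoxyphenyl group of compound 1 stands apart, with an at least 9.6-fold lower number from compound 1 to compound 4 (0.98 log units; beyond the scatter), a step set by a limit of the assay and not by a true number: the limit of > 25000 nM in this assay, at which 1 of the 4 values shown sits.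

The compounds shown leave open whether this tolerance extends beyond aromatic rings, for instance to a carboxylic acid, a longer alkyl chain or a plain hydrogen atom. They also cannot say whether the amine of compound 3 contributes anything, which a plain phenyl group would test, or why a single extra methoxy group in place of fluoro separates compound 1 so sharply from compound 2.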